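The source may hold more compounds than are shown below. What is called first, only, known or untested is meant among the compounds shown, and "the series" means these compounds.

In a functional assay on SW480 cells (Homo sapiens) for inhibition, read by MTT assay, with a stated time of 72 h (a lower number here means that less compound is tolerated, a higher number that more compound is tolerated), compound 1 `CC(C)(Oc1ccc(CCOc2ccc(NC(=O)c3ccccc3)cc2)cc1)C(=O)NS(=O)(=O)c1ccccc1` gives 7000 nM as a measured number. Compound 2 `CC(C)(Oc1ccc(CCOc2ccc(/N=N/c3ccccc3)cc2)cc1)C(=O)NS(=O)(=O)c1ccc(Cl)cc1` stands at > 24000 nM in this assay and that reading is a limit, not a number. The change to compound 3 `CC(C)(Oc1ccc(CCOc2ccc(/N=N/c3ccccc3)cc2)cc1)C(=O)NS(=O)(=O)c1ccc([N+](=O)[O-])cc1` is nitro in place of chloro on an aromatic carbon, para to a large group (nitro in place of chloro on an aromatic carbon) and nothing else. Among the measured compounds shown here, no measured pair shows this swap, so no step beyond the usual scatter is expected in this assay in either direction. The estimated step that the limit leaves unreadable from compound 2 to compound 3 stays within that scatter. Compound 3 is expected at 26000 nM within a range of 10000 nM to 60000 nM for the measurement.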

Compound 3, half-maximal cytotoxic concentration: > 24000 nM
Compound 3: only a limit was reported; the forecaster's own chance of this, stated with the estimate: 55%; the middle value lies beyond the limit too.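

No step can be read from compound 2 to compound 3, because both readings are limits, not numbers: the limit of > 24000 nM in this assay, at which 2 of the 3 values shown sit. The compounds shown leave open whether nitro in place of chloro shifts the half-maximal cytotoxic concentration at all, and in which direction.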